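The source may report more compounds than this note shows. Statements on the series, on what has been measured and on what is new or still open speak of the compounds shown alone.

Of the compounds shown here, three built on one shared core have been measured in an ADME assay on BJ cells (Homo sapiens) for cytotoxicity, with a stated time of 72 h; a higher number here means that more compound is needed for the effect, a lower number that less compound is needed. Compound 1 `Cc1cc(NC(=O)Nc2cccc(C(N)=O)c2)c2ccccc2n1` gives only a limit there, > 25000 nM. Compound 2 `Cc1ccc(NC(=O)Nc2cc(C)nc3ccccc23)cc1` likewise gives only a limit, > 25000 nM. For the measured compounds named here, compound 3 `COC(=O)c1cccc(NC(=O)Nc2cc(C)nc3ccccc23)c1` gives the sole actual number among the three, 21000 nM, so it is the one measured value against which a new compound can be weighed. Going by the values given here, the single step between measured compounds that differ in one place is an at least 1.1-fold lower number from compound 1 to compound 3 (0.07 log units; that floor lies within the scatter), and since it starts from a limit it shows no real movement. Most of what is known here rests on (the limit of > 25000 nM in this assay, at which 2 of the 3 values shown sit).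

Compound 4 `Cc1cc(NC(=O)Nc2cccc(Cl)c2)c2ccccc2n1` differs from compound 3 in one place: chloro in place of methoxycarbonyl on an aromatic carbon. Among the compounds with values here, no measured step involves a chloro group, and the one step that exists ends at compound 3 with a number sitting close to the limit. The expectation for compound 4 is therefore a number around that same region, a step of a 1.2-fold higher number from compound 3 to compound 4 (0.08 log units; within the scatter) that stays within the scatter. The estimate for compound 4 in this assay is 25000 nM, with a range from 10000 nM to 60000 nM, and a fair chance that only a limit is reported once more.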

Compound 4, half-maximal effective concentration: > 25000 nM
Compound 4: a limit, no number; the forecaster's own chance of this, stated with the estimate: 55%; the middle value lies on the limit itself.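

Compound 4 carries chloro, with 1 heavy atom and 0 hydrogen-bond acceptors, on the aromatic carbon where compound 3 carries methoxycarbonyl, with 4 heavy atoms and 2 hydrogen-bond acceptors. In this assay compound 4 gives > 25000 nM, which is a limit and not a number. This replacement therefore shows an at least 1.1-fold higher number from compound 3 to compound 4 (0.07 log units; that floor lies within the scatter), so even a change this large in the group's atoms gives no readable movement at this position. The steps from compound 1 and compound 2 to compound 4 cannot be read, and most of what is known still rests on a single limit: the limit of > 25000 nM in this assay, at which 3 of the 4 values shown sit.

Going by these compounds, it remains open whether an amine, a carboxylic acid or a longer chain on this aromatic carbon would give a number clearly apart from that of compound 3. For the compounds shown here, compound 3 is still the only compound here with an actual number, so how much compound 4 really differs from it also remains open.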